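Amide-side variation on a shared spiro core

This account rests on a few compounds, and the source may have more. Where it says the series, first, only, none or still open, it means among the compounds named here.

Compounds with numbers in hand:
Compound 1 `CC(C)(C)c1ccc(C(=O)N2CCC3(CC2)C(=O)N(CC(=O)NCCC(=O)O)CN3c2ccccc2)cc1` – in an assay on HEK293 cells for displacement of a labelled ligand from NPC1-like intracellular cholesterol transporter 1 (Homo sapiens) (on this read-out lower numbers stand for stronger inhibition and higher numbers for weaker inhibition), compound 1 gives 11400 nM
Compound 2 `CC(C)(C)OC(=O)NCCCNC(=O)CN1CN(c2ccccc2)C2(CCN(C(=O)c3ccc(C(C)(C)C)cc3)CC2)C1=O` – in this assay compound 2 gives 4500 nM
Compound 3 `CC(C)(C)c1ccc(C(=O)N2CCC3(CC2)C(=O)N(CC(=O)N2CCCCC2CCO)CN3c2ccccc2)cc1` – in this assay compound 3 gives 6100 nM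

Compound 3 stands second highest of the three numbers. Its nearest neighbour is compound 2, with a 1.4-fold higher number from compound 2 to compound 3 (0.13 log units; within the scatter), and its furthest is compound 1, with a 1.9-fold lower number from compound 1 to compound 3 (0.27 log units; within the scatter); both of those gaps fall within the scatter. Among the compounds with values here, the one step that goes beyond the scatter is a 2.5-fold lower number from compound 1 to compound 2 (0.40 log units; beyond the scatter), which is modest in size.

Compound 4 `CC1CCCN(C(=O)CN2CN(c3ccccc3)C3(CCN(C(=O)c4ccc(C(C)(C)C)cc4)CC3)C2=O)C1` differs from compound 3 in one place: 3-methylpiperidin-1-yl in place of 2-(2-hydroxyethyl)piperidin-1-yl on a carbonyl carbon. Within the data shown here, no measured pair shows this particular exchange. What the measured steps do show is that changes at the group on this carbonyl carbon, whether toward the open chain of compound 1 or the carbamate-bearing chain of compound 2, move the number only by small amounts, mostly within the scatter. On that basis the step for compound 4 is expected to be a 1.1-fold higher number from compound 3 to compound 4 (0.03 log units; within the scatter), that is, no step beyond the scatter in either direction. Compound 4 is therefore estimated at 6500 nM in this assay, with a range from 2500 nM to 17000 nM.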

Compound 4, half-maximal inhibitory concentration: 12000 nM
For compound 4 the middle estimate is 1.8-fold (0.27 log units) below the measured one; low and high end bracket the measured number.
By their numbers in this assay, from the lowest: compounds 2, 3, 1 and 4 (each within the scatter of the next, the first and the last beyond it).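

In this assay, exchanging 2-(2-hydroxyethyl)piperidin-1-yl for 3-methylpiperidin-1-yl, an entering group with no hydrogen-bond donors or acceptors, gives only a small change (a 2.0-fold higher number from compound 3 to compound 4 (0.29 log units; within the scatter)), and the open chain of compound 1 cannot be told apart from the 3-methylpiperidin-1-yl group either (a 1.1-fold higher number from compound 1 to compound 4 (0.02 log units; within the scatter)). The carbamate-bearing chain, by contrast, now differs from this ring as well as from the carboxy-ended chain (a 2.7-fold higher number from compound 2 to compound 4 (0.43 log units; beyond the scatter)), so compound 2 stands apart from both compound 1 and compound 4, although compound 3 stands apart from none of the others and the gaps remain modest. Nothing on hand accounts for these differences or says why such unlike groups on this carbonyl carbon give similar numbers.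

The compounds shown leave open whether the hydroxyethyl and methyl substituents matter at all, which unsubstituted piperidin-1-yl or 2-methylpiperidin-1-yl on the same carbonyl carbon would help to settle. They also leave open whether the lower number of compound 2 belongs to its carbamate or to its longer chain, a question that a free primary amine or a plain butyl chain in that place would address.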